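Ester Swap and Expected Stability of Compound 4

This account rests on a few compounds, and the source may have more. Where it says the series, first, only, none or still open, it means among the compounds named here.

Measured compounds:
compound 1 `C[C@@H](O)[C@H]1C(=O)N2C(C(=O)OCOC(=O)C(C)(C)C)=C(S[C@@H]3CN[C@H](C(=O)Nc4cccc(C(=O)O)c4)C3)[C@H](C)[C@H]12` – > 95%
compound 2 `C[C@@H](O)[C@H]1C(=O)N2C(C(=O)OCC(F)(F)F)=C(S[C@@H]3CN[C@H](C(=O)Nc4cccc(C(=O)O)c4)C3)[C@H](C)[C@H]12` – > 95%
compound 3 `C[C@@H](O)[C@H]1C(=O)N2C(C(=O)O)=C(S[C@@H]3CN[C@H](C(=O)Nc4cccc(C(=O)OCC(F)(F)F)c4)C3)[C@H](C)[C@H]12` – > 95%

Of the compounds shown here, three have been tested in an ADME assay for metabolic stability, read by LC-MS, with a stated time of 3 h, at pH 6.5, tested at 50 uM; on this read-out higher numbers stand for a more stable compound and lower numbers for a less stable compound. Compound 1 reaches a limit of the assay at > 95%. Compound 2 likewise sits at a limit of the assay, > 95%. Compound 3 also returns only a limit, > 95%.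

Compound 2 and compound 1 differ in one place, (((tert-butyl)carbonyl)oxy in place of trifluoromethyl on a saturated chain carbon bound to an oxygen next to a carbonyl group), and the step that the two limits leave unreadable from compound 2 to compound 1 cannot be read because both ends are limits. Compound 2 and compound 3 carry the same atoms joined differently, and the difference between the two cores is not broken down here.

Compound 4 `C[C@@H](O)[C@H]1C(=O)N2C(C(=O)O)=C(S[C@@H]3CN[C@H](C(=O)Nc4cccc(C(=O)OCOC(=O)C(C)(C)C)c4)C3)[C@H](C)[C@H]12` has not yet been measured. It differs from compound 3 by ((tert-butyl)carbonyl)oxy in place of trifluoromethyl on a saturated chain carbon bound to an oxygen next to a carbonyl group, the same change that separates compound 2 from compound 1, and at the same place. Going by the values given here, since all three measured values sit at the limit of > 95% in this assay, at which 3 of the 3 values shown sit, the first occurrence of this change gives no readable size, and nothing among the measured compounds points away from that limit for the second one.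

Compound 4 is therefore expected to return a value at or near the same limit, with an estimated step that the limit leaves unreadable from compound 3 to compound 4 from compound 3. The estimate for compound 4 is 96%, within 88% to 100%, and it is expected that this assay will most likely again report only a limit.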

Compound 4, percent of the compound remaining: > 95%
Compound 4: a limit, no number; the forecaster's own chance of this, stated with the estimate: 85%; the middle value is on the limit's open side.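

In this assay compound 4 gives > 95%, which is a limit of the assay and not a number. No step can be read between compound 3 and compound 4, as both ends are limits: the limit of > 95% in this assay, at which 4 of the 4 values shown sit.

The compounds shown leave open whether ((tert-butyl)carbonyl)oxy in place of trifluoromethyl changes the result in this assay at all, and how the four compounds would rank without that limit.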